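The compounds below may be only part of what the source reports. "The series", "measured", "known", "first", "only" and "open" are said of these compounds alone.

Compound 1 `Cc1ccc(C(=O)OC2(C(=O)Nc3ccc([N+](=O)[O-])cc3)CCCCC2)cc1`, compound 2 `O=C(OC1(C(=O)Nc2ccc([N+](=O)[O-])cc2)CCCCC1)c1ccc(Br)cc1` and compound 3 `O=C(OC1(C(=O)Nc2ccc([N+](=O)[O-])cc2)CCCCC1)c1ccccc1` share one core and differ only in the group carried on the aromatic ring of the benzoyl part. In a functional assay on MCF7 cells (Homo sapiens) for inhibition, read by MTT assay, with a stated time of 72 h (on this read-out higher numbers stand for weaker inhibition and lower numbers for stronger inhibition), compound 1 gives 9.8 nM, compound 2 gives 237 nM and compound 3 gives 903 nM; compound 3 thus has the highest number and is the weakest inhibitor of the three, through the steps of a 3.8-fold higher number from compound 2 to compound 3 (0.58 log units; beyond the scatter) and a 92-fold higher number from compound 1 to compound 3 (1.96 log units; beyond the scatter). Compound 4 `O=C(Nc1ccc([N+](=O)[O-])cc1)C1(O)CCCCC1` removes that whole group: hydrogen in place of benzoyl on an oxygen on a saturated carbon. Among the compounds with values here, none of the measured steps covers this change; they only show that altering the benzoyl ring shifts the number by a 24-fold higher number from compound 1 to compound 2 (1.38 log units; beyond the scatter) and more. Removing the benzoyl is expected to raise the number further, a step of a 3.3-fold higher number from compound 3 to compound 4 (0.52 log units; beyond the scatter). For compound 4 the expected value is 3000 nM, ranging from 600 nM to 20000 nM.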

Compound 4, half-maximal inhibitory concentration: 664 nM
Compound 4: the middle estimate sits 4.5-fold (0.65 log units) above what was measured, within the range that was stated.
By their numbers in this assay, from the lowest: compound 1; then compound 2; then compounds 4 and 3 (each within the scatter of the next).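

Swapping benzoyloxy for hydroxy on this saturated carbon gives no change beyond the scatter in this assay (a 1.4-fold lower number from compound 3 to compound 4 (0.13 log units; within the scatter)), so a bare benzoyl is not distinguishable from the free hydroxy. The bromo and methyl benzoyl esters do stand apart from compound 4 (a 2.8-fold higher number from compound 2 to compound 4 (0.45 log units; beyond the scatter); a 68-fold higher number from compound 1 to compound 4 (1.83 log units; beyond the scatter)), so the low numbers go with the substituted ring and not with the ester alone. Nothing here accounts for this pattern.

Still open, from the compounds shown here alone, is whether an ethyl group in place of methyl on the ring would keep the number of compound 1, and how an amine in place of hydroxy would read.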